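From methoxy to methoxycarbonyl on an aromatic carbon

The compounds below may be only part of what the source reports. "The series", "measured", "known", "first", "only" and "open" are said of these compounds alone.

Compound 1 `C=CC(=O)N1C(=O)CC(c2ccc(OC)cc2)Sc2ccccc21`: 32900 nM
Compound 2 `C=CC(=O)N1C(=O)CC(c2cccc(Cl)c2)Sc2ccccc21`: 31700 nM

These two numbers come from a functional assay on NB-4 cells (Homo sapiens) for cytotoxicity, read by CCK-8 assay, with a stated time of 24 h (on this read-out higher numbers stand for weaker inhibition and lower numbers for stronger inhibition), and they lie within the scatter of each other. Compound 1 therefore holds no separate place and shares its level with compound 2. Compound 3 `C=CC(=O)N1C(=O)CC(c2ccc(C(=O)OC)cc2)Sc2ccccc21` keeps the core of compound 1 and differs by methoxycarbonyl in place of methoxy on an aromatic carbon, para to a large group. Within the data shown here, only one measured step exists, a 1.0-fold lower number from compound 1 to compound 2 (0.02 log units; within the scatter), with 3-chlorophenyl in place of 4-methoxyphenyl on a saturated ring carbon. Among the measured compounds shown here, it bears on the new change only loosely, and no measured pair exchanges methoxy for methoxycarbonyl. With that single step as a guide, no change beyond the scatter is expected in this assay, and neither direction is favoured. The expected step is a 1.1-fold lower number from compound 1 to compound 3 (0.04 log units; within the scatter). For compound 3 the estimated value is 30000 nM, with an expected range of 12000 nM to 70000 nM.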

Compound 3, half-maximal inhibitory concentration: 24400 nM
Beside the measured number, compound 3's estimate is 1.2-fold (0.09 log units) above it; low and high end bracket the measured number.
By their numbers in this assay, from the lowest: compounds 3, 2 and 1 (each within the scatter of the next).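

In this assay, the exchange of methoxy for methoxycarbonyl on an aromatic carbon, para to a large group, gives a 1.3-fold lower number from compound 1 to compound 3 (0.13 log units; within the scatter) and so leaves the read-out within the scatter. The earlier step had replaced 4-methoxyphenyl with 3-chlorophenyl, changing both the group and its place on the ring, whereas this step alters the group alone and keeps its place. It shows that the larger methoxycarbonyl group, with its double bond outside aromatic rings and its additional hydrogen-bond acceptor, brings no change beyond the scatter at this position, and nothing available here accounts for that result.

Going by these compounds, whether an amine, a carboxylic acid or a longer chain at this place would behave the same way remains open. Also open is whether any group here can move the number beyond the scatter, as every step shown stays within it.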